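Notes on a diarylidene series in lung cancer cells

The source may report more compounds than this note shows. Statements on the series, on what has been measured and on what is new or still open speak of the compounds shown alone.

Compound 1 `COc1ccccc1/C=c1/[nH]c(=O)/c(=C\c2ccccc2OC)n(C)c1=O` gives 16900 nM in a functional assay on NCI-H1975 cells (Homo sapiens) for cytotoxicity, read by CCK-8 assay, with a stated time of 72 h; a lower number here means a stronger inhibitor, a higher number a weaker inhibitor. Compound 2 `C=CCn1c(=O)/c(=C\c2ccccc2Cl)[nH]c(=O)/c1=C\c1ccccc1OC` gives 9200 nM in this assay; of the two numbers given, compound 2 has the one that is lower, yet the gap to compound 1 is within the scatter, so no ranking follows. Compound 3 `COc1ccccc1/C=c1/[nH]c(=O)/c(=C\c2ccccc2OC)[nH]c1=O` gives "not active" (no number reported) in this assay, so no number stands for it. Compound 4 `C=CCn1c(=O)/c(=C\c2cccc(C)c2)[nH]c(=O)/c1=C\c1ccccc1OC` is not yet measured in this assay. Against compound 2 it carries 3-methylphenyl in place of 2-chlorophenyl on a double-bonded chain carbon bound to an aromatic carbon. Within the data shown here, no measured pair shows this change, so no step can be read from the data. The expected step is a 1.3-fold higher number from compound 2 to compound 4 (0.12 log units; within the scatter), none beyond the scatter. Compound 4 is thus estimated at 12000 nM in this assay, within a range of 4000 nM to 40000 nM.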

Compound 4, half-maximal inhibitory concentration: 32800 nM
Compound 4: the middle estimate sits 2.7-fold (0.44 log units) below what was measured; measured number inside the range.
By their numbers in this assay, from the lowest: compounds 2, 1 and 4 (each within the scatter of the next, the first and the last beyond it).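

Among these compounds, the first readable step at this place, a double-bonded chain carbon bound to an aromatic carbon, comes from putting 3-methylphenyl in place of 2-chlorophenyl: in this assay the change gives a 3.6-fold higher number from compound 2 to compound 4 (0.55 log units; beyond the scatter) and so shows that the aryl group here is not interchangeable. Both groups have the same heavy atom count, yet they differ in substituent and in its ring position, so this single step cannot separate the two. No measurement at hand accounts for the step.

Open, from the compounds shown here alone, is whether 2-methylphenyl or 3-chlorophenyl would separate those two differences. Also open, going by these compounds, is how a phenyl ring bearing an amine or a carboxylic acid would read at this place.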